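Trimming the amide: from butylcarbamoyl to carbamoyl

The compounds below may be only part of what the source reports. "The series", "measured", "known", "first", "only" and "open" are said of these compounds alone.

Of the compounds shown here, two sharing one core have been tested in a functional assay for inhibition of nuclear factor NF-kappa-B complex (Homo sapiens); on this read-out lower numbers stand for stronger inhibition and higher numbers for weaker inhibition. Compound 1 `CCOCC1=Cc2ccc(OC)cc2OC1c1cc(OC)c(OC)c(OC)c1` gives 21300 nM, and compound 2 `CCCCNC(=O)C1=Cc2ccc(OC)cc2OC1c1cc(OC)c(OC)c(OC)c1` gives 25500 nM. Within the data shown here, the only step between them, a 1.2-fold higher number from compound 1 to compound 2 (0.08 log units; within the scatter), is within the scatter, so the two values cannot be told apart, and compound 2 stands together with compound 1 at the weak end of what has been seen.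

Compound 3 `COc1ccc2c(c1)OC(c1cc(OC)c(OC)c(OC)c1)C(C(N)=O)=C2` is the next compound, not yet measured. Its change from compound 2 is hydrogen in place of butyl on an amide-type nitrogen. Among the measured compounds shown here, no measured step bears directly on this change: the only step on record, a 1.2-fold higher number from compound 1 to compound 2 (0.08 log units; within the scatter), swaps the whole side group on the ring carbon rather than trimming the amide, and it moved the number by less than the scatter. Nothing in the data therefore points toward a shift in either direction beyond the scatter, and compound 3 is expected to stay close to compound 2, with a 1.2-fold higher number from compound 2 to compound 3 (0.07 log units; within the scatter). The estimate for compound 3 in this assay is 30000 nM, with a range from 10000 nM to 90000 nM.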

Compound 3, half-maximal inhibitory concentration: > 50000 nM
Compound 3 was reported as a limit (the forecaster's own chance of this, stated with the estimate: 15%); middle value at least 1.6-fold (0.22 log units) away from the limit.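

In this assay compound 3 gives > 50000 nM, which is a limit of the assay and not a number: the limit of > 50000 nM in this assay, at which 1 of the 3 values shown sits. Cutting the amide back to carbamoyl gives an at least 1.9-fold higher number from compound 2 to compound 3 (0.29 log units; that floor lies within the scatter), and since that floor lies within the scatter, the loss of butyl on the amide-type nitrogen cannot yet be said to weaken inhibition, although the true value of compound 3 may lie well beyond the floor. The position on the double-bonded ring carbon does now show a difference: carbamoyl in place of ethoxymethyl gives an at least 2.3-fold higher number from compound 1 to compound 3 (0.37 log units; beyond the scatter), which is beyond the scatter, whereas butylcarbamoyl in place of ethoxymethyl gave only a 1.2-fold higher number from compound 1 to compound 2 (0.08 log units; within the scatter), so the choice of group at this carbon can matter.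

The limit leaves the full size of both new steps open, and so it remains unclear how much the butyl contributes. The compounds shown also do not say whether a methyl or a longer chain such as hexyl on the amide-type nitrogen, or a carboxylic acid or an amine on the double-bonded ring carbon, would bring the number below those seen so far.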